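The compounds below may be only part of what the source reports. "The series", "measured", "known", "first", "only" and "open" are said of these compounds alone.

Of the compounds shown here, three have been measured in an assay on HEK293 cells for positive allosteric modulation of metabotropic glutamate receptor 2 (Rattus norvegicus), read by thallium flux; a lower number here means that less compound is needed, a higher number that more compound is needed for the effect: compound 1 `O=C(O)c1cc(-c2cccc(COc3ccc4c(=O)n(C5CCCC5)oc4c3)c2)ccc1Cl` gives 310 nM; compound 2 `CC(C)N1Cc2cc(OCc3cccc(-c4ccc(Cl)c(C(=O)O)c4)c3)ccc2C1=O` gives 70 nM; compound 3 `O=C(O)c1cc(-c2cccc(COc3ccc4c(c3)CCN(C3CCCC3)C4=O)c2)ccc1Cl` gives 300 nM.

Compound 2 stands lowest of the three numbers, and both compound 1 and compound 3 lie higher by margins beyond the usual scatter. Compound 4 `O=C(O)c1cc(-c2cccc(COc3ccc4c(c3)CN(C3CCCCC3)C4=O)c2)ccc1Cl` departs from compound 2 by one change: cyclohexyl in place of isopropyl on an amide-type nitrogen in a ring. For the measured compounds named here, no measured pair isolates this change. Compounds 1 and 3 carry a cyclopentyl on the same nitrogen position but on other cores, so they do not show the ring effect on its own. In this assay a modest rise is expected for compound 4, near the edge of the scatter. Compound 4 is estimated at 150 nM, in a range of 50 nM to 500 nM, a step of a 2.1-fold higher number from compound 2 to compound 4 (0.33 log units; beyond the scatter) from its parent.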

Compound 4, half-maximal effective concentration: 270 nM
The estimate for compound 4 lay 1.8-fold (0.26 log units) below the measured number; measured number inside the range.
By their numbers in this assay, from the lowest: compound 2; then compounds 4, 3 and 1 (each within the scatter of the next).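

In this assay, for the compounds shown here, cyclohexyl in place of isopropyl on the amide-type nitrogen in a ring gives a 3.9-fold higher number from compound 2 to compound 4 (0.59 log units; beyond the scatter) on an otherwise unchanged structure, the first reading of a single change at this position. It shows that the number responds to the group on this nitrogen, and that of these two groups isopropyl goes with the lower number. Nothing available explains this step.

From the compounds shown here alone, whether a smaller group such as cyclopropyl or methyl would give a lower number than isopropyl remains open. So does the outcome for a ring holding oxygen, such as tetrahydropyranyl, at this position.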